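This account rests on a few compounds, and the source may have more. Where it says the series, first, only, none or still open, it means among the compounds named here.

Measured compounds and their values:
- compound 1, `CCn1c(=O)[nH]c2c(cnn2-c2cccc(Cl)c2)c1=N`: 70%
- compound 2, `CCCn1c(=O)[nH]c2c(cnn2-c2cccc(Cl)c2)c1=N`: 68%
- compound 3, `Cn1c(=O)[nH]c2c(cnn2-c2ccc(Br)cc2)c1=N`: 34%

All three share one core and were tested in an assay on membranes from brain for binding affinity to adenosine receptor A1 (Rattus norvegicus), read by radioligand binding, tested at 20 uM; a lower number here means less inhibition, a higher number more inhibition at the concentration tested (going by the name of the read-out). Compound 1 and compound 2 differ only in the chain on a ring nitrogen, and the step of a number 2 percentage points lower from compound 1 to compound 2 (within the scatter) stays within the scatter, so lengthening that chain by one carbon leaves the read-out where it was. Compound 3 stands lowest of the three, and its gap to each of the other two lies beyond the scatter.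

The next compound, compound 4, is `Cn1c(=O)[nH]c2c(cnn2-c2ccc([N+](=O)[O-])cc2)c1=N`. It differs from compound 3 in one place: nitro in place of bromo on an aromatic carbon

Within the data shown here, only one measured step exists, and it concerns the chain on the ring nitrogen, not the six-membered aromatic ring of carbon only where this exchange happens. Among the measured compounds shown here, no measured pair swaps a group on that ring, so there is no basis for a direction. The step of a number 4 percentage points lower from compound 3 to compound 4 (within the scatter) is therefore expected to be none beyond the scatter, with a wide range to reflect the lack of comparable data. Compound 4 is estimated at 30%, with a range from 5% to 60%.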

Compound 4, a percentage reported as inhibition, at one concentration (the size of the read-out at that concentration, not a potency): 5%
Beside the measured number, compound 4's estimate is 25 percentage points above it, and the stated range covers the measured number.
By their numbers in this assay, from the lowest: compound 4; then compound 3; then compounds 2 and 1 (each within the scatter of the next).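

Nitro in place of bromo on an aromatic carbon is the first measured exchange on the six-membered aromatic ring of carbon only, and in this assay it comes out as a number 29 percentage points lower from compound 3 to compound 4 (beyond the scatter); unlike the one-carbon lengthening of the chain on the ring nitrogen, it moves the read-out, so the group at this place, para to a large group, matters for this pair. Compound 4, at 5%, has the lowest number of the four, although this is inhibition at a single concentration and not a potency. Nothing measured here says which feature of the nitro group lies behind the drop, even though the exchange replaces one heavy atom with three and adds two hydrogen-bond acceptors.

One pair gives no trend across groups at this place, and compound 1 and compound 2 differ from compound 3 in more than one place, so they cannot extend it. From the compounds shown here alone, whether an amine, a methoxy group or plain hydrogen at the same place would sit near compound 3, near compound 4 or elsewhere remains open.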